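A few compounds are considered here, and "the series" means these few. Any claim that something is new, unique, unknown or untested is made for them only; others in the source may bear on it.

Measured so far:
compound 1 `CC(C(=O)NCc1ccc(C(F)(F)F)cc1N1CCN(C2CCCCC2)CC1)c1ccc(NS(C)(=O)=O)c(F)c1`: 13.8 nM
compound 2 `CC(C(=O)NCc1ccc(C(F)(F)F)cc1SCc1ccco1)c1ccc(NS(C)(=O)=O)c(F)c1`: 3.2 nM

For the measured compounds named here, compound 2 gives the lowest number of the two; the only other compound, compound 1, is the nearest, and the step of a 4.3-fold lower number from compound 1 to compound 2 (0.63 log units; beyond the scatter) separates them. Compound 3 `CC(C(=O)NCc1ccc(C(F)(F)F)cc1Cl)c1ccc(NS(C)(=O)=O)c(F)c1` is made from compound 2 by the change (chloro in place of ((furan-2-yl)methyl)sulfanyl on an aromatic carbon). Going by the values given here, no measured step matches this change: the one step seen swapped one large group for another large group at the same carbon, whereas here a large group is replaced by a single atom. That step was modest in size, which suggests this position tolerates change without large swings. A modest rise in the number, beyond the scatter but not large, is therefore expected: the step for compound 3 is estimated at a 2.5-fold higher number from compound 2 to compound 3 (0.40 log units; beyond the scatter). Compound 3 is expected to give an estimate of 8 nM in an assay on CHO cells for antagonist activity at transient receptor potential cation channel subfamily V member 1 (Homo sapiens), read by FLIPR (a lower number here means a stronger inhibitor, a higher number a weaker inhibitor), within a range from 2.5 nM to 25 nM.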

Compound 3, inhibition constant: 4 nM
Compound 3: middle estimate off by 2.0-fold (0.30 log units), on the high side; the measured number falls inside the stated range.
By their numbers in this assay, from the lowest: compounds 2 and 3 (each within the scatter of the next); then compound 1.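

In this assay, a single chlorine atom does the job of a much larger group at this aromatic carbon: the step is a 1.3-fold higher number from compound 2 to compound 3 (0.10 log units; within the scatter), so the ((furan-2-yl)methyl)sulfanyl group, with its five-membered aromatic ring, is not needed for a low number here. The other comparison, a 3.5-fold lower number from compound 1 to compound 3 (0.54 log units; beyond the scatter), shows that a large group and a single atom can read alike at this position, while the other large group, 4-cyclohexylpiperazin-1-yl in compound 1, stands apart, so group size alone does not order these three compounds. No measurement is available to explain these results. The compounds shown leave open whether a bare hydrogen, a methoxy group or a simple amine at this carbon would read like chloro or like 4-cyclohexylpiperazin-1-yl. They also leave open which part of 4-cyclohexylpiperazin-1-yl, the cyclohexyl or the piperazine, goes with its higher number.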